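From 2-chlorophenyl to 4-chlorophenyl on a saturated chain

The source may report more compounds than this note shows. Statements on the series, on what has been measured and on what is new or still open speak of the compounds shown alone.

In a functional assay on PANC-1 cells (Homo sapiens) for cytotoxicity, read by WST assay, with a stated time of 24 h (a higher number here means a weaker inhibitor, a lower number a stronger inhibitor), compound 3 (`O=C(CCCCCCCCc1ccccc1Cl)N1CCCCC1`) gives > 100000 nM as its result, which is a limit and not a number. Compound 1 (`O=C(CCCCCCCCCc1ccccc1)N1CCCCC1`) gives > 100000 nM as a limit too. Only compound 2 (`O=C(CCCCCCCCc1ccc(C(F)(F)F)cc1)N1CCCCC1`) gives a number, at 54000 nM in that assay. Compound 4 (`O=C(CCCCCCCCc1ccc(Cl)cc1)N1CCCCC1`) carries 4-chlorophenyl in place of 2-chlorophenyl on a saturated chain carbon, eight bonds along the chain from a carbonyl carbon. Among the compounds with values here, the one measured step nearby is a step that the two limits leave unreadable from compound 1 to compound 3 and offers no size. Within the data shown here, with compound 2 at 54000 nM as the sole number, a modest move towards stronger inhibition is expected. Another limit remains possible for compound 4. The expected change is an at least 1.2-fold lower number from compound 3 to compound 4 (0.09 log units; that floor lies within the scatter) at best. In this assay the estimate for compound 4 is 80000 nM with an expected range from 40000 nM to 150000 nM overall.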

Compound 4, half-maximal inhibitory concentration: 65500 nM
Compound 4: middle estimate off by 1.2-fold (0.09 log units), on the high side; the measured number falls inside the stated range.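

In this assay, 4-chlorophenyl gives a readable number at this place on the chain where 2-chlorophenyl gives only a limit, with an at least 1.5-fold lower number from compound 3 to compound 4 (0.18 log units; that floor lies within the scatter) and an at least 1.5-fold lower number from compound 1 to compound 4 (0.18 log units; that floor lies within the scatter). These two steps are floors and not sizes, because each starts from a limit: the limit of > 100000 nM in this assay, at which 2 of the 4 values shown sit. Chloro in place of trifluoromethyl on an aromatic carbon gives a 1.2-fold higher number from compound 2 to compound 4 (0.08 log units; within the scatter), so the two groups are not told apart here.

From the compounds shown here alone, how far the number would move with a carboxylic acid or an amine in place of the chloro remains open. Going by these compounds, the effect of a longer chain carrying 4-chlorophenyl also remains open.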